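Hexyloxy for cyclohexylamino: cytotoxicity on a purine-like core

A few compounds are considered here, and "the series" means these few. Any claim that something is new, unique, unknown or untested is made for them only; others in the source may bear on it.

Measured so far:
compound 1 `Nc1nc(NC2CCCCC2)c2ncn(/C=C3/CC3(CO)CO)c2n1` — "not determined" (no result reported)
compound 2 `CC(C)CSc1nc(N)nc2c1ncn2/C=C1/CC1(CO)CO` — "not determined" (no result reported)
compound 3 `CCOc1nc(N)nc2c1ncn2/C=C1/CC1(CO)CO` — > 20000 nM

Three compounds share a core and a methylenecyclopropane diol side chain, and differ only in the group on one aromatic carbon. In an ADME assay on MOLT-3 cells (Homo sapiens) for cytotoxicity, with a stated time of 7 days (on this read-out higher numbers stand for lower toxicity in this test and lower numbers for higher toxicity in this test), compound 1 gives "not determined" (no result reported), so no number places it. Compound 2 likewise gives "not determined" (no result reported) in this assay. Compound 3 is the only one with a reported result, and that result is a limit of this assay, not a number: compound 3 gives > 20000 nM and thus sits at the limit of > 20000 nM in this assay, at which 1 of the 3 values shown sits.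

The unmeasured compound 4 `CCCCCCOc1nc(N)nc2c1ncn2/C=C1/CC1(CO)CO` arises from compound 1 through (hexyloxy in place of cyclohexylamino on an aromatic carbon). Among the compounds with values here, no measured step connects these two, so the size of the change in this assay cannot be read from the data; given that the only reported value is a limit, the expectation is that compound 4 also shows no measurable toxicity rather than a step beyond the scatter in either direction. Compound 4 is therefore estimated at 20000 nM, within 5000 nM to 60000 nM.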

Compound 4, half-maximal cytotoxic concentration: > 20000 nM
Compound 4: no number, only a limit (the forecaster's own chance of this, stated with the estimate: 75%); the middle value sits exactly at the limit.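

No step can be read from compound 3 to compound 4, because both results are limits and not numbers: the limit of > 20000 nM in this assay, at which 2 of the 4 values shown sit. The compounds shown leave open how far each compound lies beyond that limit, and whether butyl in place of hydrogen on the chain changes toxicity at all.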